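Working notes on the shared core: propargyl thioether step

The source may report more compounds than this note shows. Statements on the series, on what has been measured and on what is new or still open speak of the compounds shown alone.

Compound 1, `C#CCSc1nnc(CC)n1N1C(=O)c2ccccc2C1=O`: in a functional assay on PC-3M cells (Homo sapiens) for cytotoxicity, read by MTT assay, with a stated time of 48 h (on this read-out higher numbers stand for weaker inhibition and lower numbers for stronger inhibition), compound 1 gives > 200000 nM, a limit of the assay.
Compound 2, `CCCc1nnc(SCC(=O)c2ccc(Cl)cc2)n1N1C(=O)c2ccccc2C1=O`: in this assay compound 2 gives > 200000 nM, a limit.
Compound 3, `CCCc1nnc(SCC(=O)c2ccc(C)cc2)n1N1C(=O)c2ccccc2C1=O`: in this assay compound 3 gives > 200000 nM, a limit.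

Compound 3 stands at the limit, as do the two other values shown (the limit of > 200000 nM in this assay, at which 3 of the 3 values shown sit). Among the compounds with values here, the only single-point step, a step that the two limits leave unreadable from compound 2 to compound 3, is therefore unreadable.

Compound 4, `C#CCSc1nnc(CCC)n1N1C(=O)c2ccccc2C1=O`, differs from compound 3 by ethynyl in place of (4-methylphenyl)carbonyl on a saturated chain carbon bound to a sulfur. Within the data shown here, no measured step bears on this change, and the one step measured was unreadable. Compound 1, which carries the same propargyl thioether on a shorter chain, also sits at the limit. Compound 4 is therefore expected to give a limit again, with an estimated step that the limit leaves unreadable from compound 3 to compound 4 not readable. The estimate for compound 4 is 300000 nM, range 150000 nM to 1000000 nM.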

Compound 4, half-maximal inhibitory concentration: > 200000 nM
Compound 4 gave a limit, no number; the forecaster's own chance of this, stated with the estimate: 90%; the middle value lies beyond the limit too.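

Compound 4 sits at the limit with compound 1, compound 2 and compound 3, so no step among these compounds can be read: the limit of > 200000 nM in this assay, at which 4 of the 4 values shown sit.

The compounds shown leave open which change on the shared core, if any, would give a readable value in this assay.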